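Chloro for Methyl, Repeated on a Second Core

The source may hold more compounds than are shown below. What is called first, only, known or untested is meant among the compounds shown, and "the series" means these compounds.

Compound 1 `Cc1ccc2nc(Nc3nc(Nc4ccc(S(N)(=O)=O)cc4)ncc3C)sc2c1` and compound 2 `Cc1cnc(Nc2ccc(S(N)(=O)=O)cc2)nc1Nc1nc2ccc(Cl)cc2s1` are built on one shared core, while compound 3 `Cc1ccc2nc(Nc3ccnc(Nc4ccc(S(C)(=O)=O)cc4)n3)sc2c1` and compound 4 `CS(=O)(=O)c1ccc(Nc2nccc(Nc3nc4ccc(Cl)cc4s3)n2)cc1` are built on another; how the two cores differ is not broken down here. All were examined in a functional assay on HeLa cells (Homo sapiens) for antiproliferative activity, read by MTT assay, with a stated time of 48 h; a higher number here means a weaker inhibitor, a lower number a stronger inhibitor. In this assay compound 1 gives 3280 nM and compound 2 gives 3730 nM. Among the compounds with values here, the one change between them is chloro in place of methyl on an aromatic carbon and it made a step of a 1.1-fold higher number from compound 1 to compound 2 (0.06 log units; within the scatter). Compound 3 gives 2300 nM, and this number sits within the usual scatter of those for compound 1 and compound 2, so no order among the three can be read. Compound 4 differs from compound 3 by chloro in place of methyl on an aromatic carbon, the same change at the same place, now on the second core. Within the data shown here, because the one earlier example of this change gave a 1.1-fold higher number from compound 1 to compound 2 (0.06 log units; within the scatter), a step of similar size is expected on the second core as well. Compound 4 is therefore estimated at 2600 nM, expected to lie between 1300 nM and 5200 nM. The expected step is a 1.1-fold higher number from compound 3 to compound 4 (0.05 log units; within the scatter), resting on that single precedent.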

Compound 4, half-maximal inhibitory concentration: 1400 nM
Compound 4: the middle estimate sits 1.9-fold (0.27 log units) above what was measured; the range from low to high includes it.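

Putting chloro in place of methyl on the second core gave a 1.6-fold lower number from compound 3 to compound 4 (0.22 log units; within the scatter), so in this assay this step, like the earlier one, is too small to tell apart from the ordinary spread of repeated measurements. Set side by side, the two steps do not differ in any way these numbers can detect: the same change on two cores in this assay, a 1.1-fold higher number (0.06 log units; within the scatter) from compound 1 to compound 2 and a 1.6-fold lower number (0.22 log units; within the scatter) from compound 3 to compound 4, 1.9-fold (0.27 log units) apart, within the scatter of two such steps. This shows that on both cores the change left the number within the scatter, but it does not show that chloro and methyl are truly equivalent, and two pairs are too few to say the same would hold on a further core.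

The compounds shown leave open what other groups at this same place would do on either core, such as a methoxy group, an amine, a carboxylic acid or a longer chain. They also leave open whether any change at this place can move the number beyond the scatter.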